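From an amide tail to a benzyl tail on compound 2

The source may report more compounds than this note shows. Statements on the series, on what has been measured and on what is new or still open speak of the compounds shown alone.

Compound 2 `COc1cc(-c2nc3cc(/C=C4\SC(=O)N(CC(=O)N5CCOCC5)C4=O)ccc3[nH]2)cc(OC)c1OC` gives 14900 nM in a functional assay on MDA-MB-231 cells (Homo sapiens) for inhibition, read by MTT assay, with a stated time of 48 h (a higher number here means a weaker inhibitor, a lower number a stronger inhibitor), the second highest of the three numbers recorded so far, with both neighbours within the scatter of it. Among the compounds with values here, compound 1 `COc1cc(-c2nc3cc(/C=C4\SC(=O)NC4=O)ccc3[nH]2)ccc1OCC(C)C` gives 7780 nM and compound 3 `COc1cc(OC)c(-c2nc3cc(/C=C4\SC(=O)N(CC(=O)N5CCOCC5)C4=O)ccc3[nH]2)cc1OC` gives 21300 nM; the only single-place step, a 1.4-fold higher number from compound 2 to compound 3 (0.16 log units; within the scatter), stays within the scatter. Compound 4 `COc1cc(-c2nc3cc(/C=C4\SC(=O)N(Cc5cccc(C)c5)C4=O)ccc3[nH]2)cc(OC)c1OC` differs from compound 2 by 3-methylphenyl in place of (morpholin-4-yl)carbonyl on a saturated chain carbon bound to an amide-type nitrogen in a ring. Within the data shown here, neither that step nor the pair of compound 1 and compound 2, which differ at more than one place, touches this part of the molecule, so no measured step bears on the change. Lacking such a precedent, compound 4 is expected to give 11000 nM (range 3000 nM to 40000 nM) in this assay, a step of a 1.4-fold lower number from compound 2 to compound 4 (0.13 log units; within the scatter) that is not expected to exceed the scatter.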

Compound 4, half-maximal inhibitory concentration: 3260 nM
For compound 4 the middle estimate is 3.4-fold (0.53 log units) above the measured one, and the stated range covers the measured number.
By their numbers in this assay, from the lowest: compound 4; then compounds 1, 2 and 3 (each within the scatter of the next, the first and the last beyond it).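

Within the data shown here, on the saturated chain carbon bound to an amide-type nitrogen in a ring, 3-methylphenyl in place of (morpholin-4-yl)carbonyl gives the first single-place step beyond the scatter in this assay: a 4.6-fold lower number from compound 2 to compound 4 (0.66 log units; beyond the scatter). The only earlier step, a 1.4-fold higher number from compound 2 to compound 3 (0.16 log units; within the scatter), lay within the scatter, so this position is the first shown to move the number. No evidence here accounts for the change.

Going by these compounds, it remains open whether the lower number follows from the ring or from its methyl, which an unsubstituted benzyl would separate. On these data alone, how a chain ending in a carboxylic acid or an amine would read also remains open.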